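Aryl for Cycloalkyl on the Thiophene Core

This account rests on a few compounds, and the source may have more. Where it says the series, first, only, none or still open, it means among the compounds named here.

Compound 3, `CC(C)c1sc(-c2ccccc2)c(C2CCCCC2)c1/C=C/[C@@H](O)C[C@@H](O)CC(=O)O`, stands lowest of the two numbers given in an assay on microsomes for inhibition of 3-hydroxy-3-methylglutaryl-coenzyme A reductase (Rattus norvegicus) (a lower number here means a stronger inhibitor, a higher number a weaker inhibitor), where compound 3 gives 202 nM. Its nearest neighbour is compound 2, `CC(C)c1sc(-c2ccccc2)c(C2CCCC2)c1/C=C/[C@@H](O)C[C@@H](O)CC(=O)O`, which in this assay gives 417 nM; the step of a 2.1-fold lower number from compound 2 to compound 3 (0.31 log units; beyond the scatter). Compound 1, `CCCCCCCCc1c(-c2ccccc2)sc(C(C)C)c1/C=C/[C@@H](O)C[C@@H](O)CC(=O)O`, reaches only a limit in this assay, > 10000 nM, (the limit of > 10000 nM in this assay, at which 1 of the 3 values shown sits). From there the steps of an at least 23-fold lower number from compound 1 to compound 2 (1.37 log units; beyond the scatter) and an at least 49-fold lower number from compound 1 to compound 3 (1.69 log units; beyond the scatter) show how much the cyclic groups gain over octyl.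

Compound 4 is `CC(C)c1sc(-c2ccccc2)c(-c2ccccc2F)c1/C=C/[C@@H](O)C[C@@H](O)CC(=O)O`. Its difference from compound 3: 2-fluorophenyl in place of cyclohexyl on an aromatic carbon. Among the compounds with values here, none of the measured steps exchanges a cycloalkyl for an aryl group, so no step bears directly on this change; the steps from octyl to cyclopentyl and cyclohexyl were large, while that between the two rings was modest. A six-membered ring stays in place, and an expectation of no step beyond the scatter is the most that can be drawn, as a 1.1-fold lower number from compound 3 to compound 4 (0.05 log units; within the scatter) expresses. Compound 4 is therefore expected to give 180 nM, with a range from 45 nM to 700 nM.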

Compound 4, half-maximal inhibitory concentration: 233 nM
Compound 4: middle estimate off by 1.3-fold (0.11 log units), on the low side, within the range that was stated.
By their numbers in this assay, from the lowest: compounds 3, 4 and 2 (each within the scatter of the next, the first and the last beyond it). At a limit, above all of these: compound 1.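

Within the data shown here, with a 1.2-fold higher number from compound 3 to compound 4 (0.06 log units; within the scatter) and a 1.8-fold lower number from compound 2 to compound 4 (0.25 log units; within the scatter) in this assay, the result shows that this position accepts an aromatic ring carrying fluorine about as well as the non-aromatic rings of the earlier compounds, neither step lying beyond the scatter. The gain over octyl also survives this change, as an at least 42-fold lower number from compound 1 to compound 4 (1.63 log units; beyond the scatter) shows, so among the compounds shown it does not depend on the ring being non-aromatic. That step has no fixed size, as compound 1 stands at a limit of the assay: the limit of > 10000 nM in this assay, at which 1 of the 4 values shown sits.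

The compounds shown leave open what the fluorine itself contributes, a question that a plain phenyl at this position would address. They also leave open whether a ring bearing an amine or a carboxylic acid would be accepted in the same way.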